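Ester side chain: from compound 3 to compound 4

The compounds below may be only part of what the source reports. "The series", "measured", "known", "first", "only" and "open" are said of these compounds alone.

In a functional assay on HeLa cells (Homo sapiens) for cytotoxicity, read by MTT assay (on this read-out lower numbers stand for stronger inhibition and higher numbers for weaker inhibition), compound 1 (`CCCC(O)CC(=O)O[C@H](CC=C(C)C)C1=CC(=O)c2c(O)ccc(O)c2C1=O`) reads 59300 nM and compound 2 (`CC(=O)OCCC(=O)O[C@H](CC=C(C)C)C1=CC(=O)c2c(O)ccc(O)c2C1=O`) reads 17300 nM, while compound 3 (`CC[C@](C)(O)CC(=O)O[C@H](CC=C(C)C)C1=CC(=O)c2c(O)ccc(O)c2C1=O`) reads 30200 nM on the same scale. Compound 3 is not separated from either of the other two (a 2.0-fold lower number from compound 1 to compound 3 (0.29 log units; within the scatter); a 1.7-fold higher number from compound 2 to compound 3 (0.24 log units; within the scatter)).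

Among the compounds with values here, compound 4 (`CCCCC(CC(=O)O[C@H](CC=C(C)C)C1=CC(=O)c2c(O)ccc(O)c2C1=O)OC(C)=O`) has no measurement yet. Relative to compound 3 it carries 1-acetoxypentyl in place of 1-hydroxy-1-methylpropyl on a saturated chain carbon bound to a carbonyl carbon.

Within the data shown here, the one step beyond the scatter is the exchange of 1-hydroxybutyl for acetoxymethyl (a 3.4-fold lower number from compound 1 to compound 2 (0.54 log units; beyond the scatter)), and it is modest. Compound 4 also bears an acetoxy-containing group, so compound 2 is the closest guide, and a shift toward a lower number is expected on that basis. Among the measured compounds shown here, no measured compound shows the effect of the longer chain alone, and the two changes cannot be separated with three compounds.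

The expected step is small (a 1.5-fold lower number from compound 3 to compound 4 (0.18 log units; within the scatter)) and is not expected to clear the scatter clearly in this assay. Compound 4 is estimated at 20000 nM within a range of 8000 nM to 50000 nM on this thin evidence.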

Compound 4, half-maximal inhibitory concentration: 73500 nM
Compound 4: middle estimate off by 3.7-fold (0.57 log units), on the low side; the whole stated range lies below it.
By their numbers in this assay, from the lowest: compounds 2, 3, 1 and 4 (each within the scatter of the next, the first and the last beyond it).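

In this assay, the acetoxy group does not by itself carry a lower number at this position: with the acetoxy kept, butyl in place of hydrogen on the saturated chain carbon bound to that oxygen gives the clearest single change in the series (a 4.2-fold higher number from compound 2 to compound 4 (0.63 log units; beyond the scatter)). Compound 3 is also separated from the new compound (a 2.4-fold higher number from compound 3 to compound 4 (0.39 log units; beyond the scatter)), although compound 3 could not be separated from either earlier compound, so 1-acetoxypentyl gives this position its first step away from 1-hydroxy-1-methylpropyl that clears the scatter. Against 1-hydroxybutyl the same group is not separated (a 1.2-fold higher number from compound 1 to compound 4 (0.09 log units; within the scatter)), so compound 1 and compound 4, one with a free hydroxyl and one with an acetoxy group, cannot be told apart here, and the earlier step toward acetoxymethyl does not extend to the longer chain.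

Still open, as far as these compounds go, is whether a 1-hydroxypentyl group would read like 1-acetoxypentyl, and whether methyl or ethyl in place of the butyl would give a smaller step or none, which would show how the number follows chain length. Nothing on hand gives a reason for these shifts.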